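A few compounds are considered here, and "the series" means these few. Any claim that something is new, unique, unknown or untested is made for them only; others in the source may bear on it.

The measured compounds:

Compound 1 `COc1nc2ccc(Br)cc2cc1C(c1ccccc1)n1cc(C2CC2)nn1` — 3.52%
Compound 2 `COc1nc2ccc(Br)cc2cc1C(c1ccccc1)n1cc(-c2ccc(Br)cc2)nn1` — 13.4%
Compound 3 `COc1nc2ccc(Br)cc2cc1C(c1ccccc1)n1cc(CCCCCO)nn1` — 8.69%

In an ADME assay on SK-OV-3 cells (Homo sapiens) for cytotoxicity, read by sulforhodamine B assay, with a stated time of 48 h, tested at 10 uM (a higher number here means more inhibition at the concentration tested (going by the name of the read-out), a lower number less inhibition), compound 3 gives 8.69%, the second highest of the three numbers. Its neighbours sit close: the step of a number 4.7 percentage points lower from compound 2 to compound 3 (within the scatter) and the step of a number 5.2 percentage points higher from compound 1 to compound 3 (within the scatter) are both within the scatter, so the three compounds cannot be told apart on these numbers.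

Compound 4 `COc1nc2ccc(Br)cc2cc1C(c1ccccc1)n1cc(CO)nn1` differs from compound 3 by hydroxy in place of 4-hydroxybutyl on a saturated chain carbon bound to an aromatic carbon. For the measured compounds named here, the steps that bear on this change are the two at the same position, a number 5.2 percentage points higher from compound 1 to compound 3 (within the scatter) and a number 4.7 percentage points lower from compound 2 to compound 3 (within the scatter), and neither moved beyond the scatter. Compound 4 is therefore expected to show no step beyond the scatter, a number 1.7 percentage points lower from compound 3 to compound 4 (within the scatter). The estimate for compound 4 is 7%, within 0% to 18%.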

Compound 4, a percentage reported as inhibition, at one concentration (the size of the read-out at that concentration, not a potency): 3.23%
Compound 4: middle estimate off by 3.8 percentage points, on the high side; the range from low to high includes it.
By their numbers in this assay, from the lowest: compounds 4, 1, 3 and 2 (each within the scatter of the next, the first and the last beyond it).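

In this assay, cutting 5-hydroxypentyl back to hydroxymethyl gives a number 5.5 percentage points lower from compound 3 to compound 4 (within the scatter), and hydroxymethyl in place of cyclopropyl gives a number 0.3 percentage points lower from compound 1 to compound 4 (within the scatter). For the compounds shown here, the first separation at this position comes with hydroxymethyl in place of 4-bromophenyl, a number 10.2 percentage points lower from compound 2 to compound 4 (beyond the scatter), the only step so far that clears the scatter, and a modest one. Nothing on hand explains that step. Still open, as far as these compounds go, is whether a plain phenyl keeps this gap from compound 4, and whether an amine or a carboxylic acid at this position would move the number at all.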